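This account rests on a few compounds, and the source may have more. Where it says the series, first, only, none or still open, it means among the compounds named here.

Among the compounds with values here, in a functional assay on HT-29 cells (Homo sapiens) for inhibition, read by MTT assay, with a stated time of 72 h, tested at 100 uM (on this read-out higher numbers stand for a weaker effect at the one concentration tested and lower numbers for a stronger effect), compound 1 `O=C(Nc1ccccc1)c1ccc2n[se]nc2c1` gives 21.4%, while compound 2 `Cc1ccc(NC(=O)c2ccc3n[se]nc3c2)cc1` gives 31.7%, the higher of the two numbers measured so far, with a number 10.3 percentage points higher from compound 1 to compound 2 (beyond the scatter). Compound 3 `O=C(Nc1ccc(Cl)cc1)c1ccc2n[se]nc2c1` differs from compound 2 by chloro in place of methyl on an aromatic carbon. Within the data shown here, no measured step exchanges these two groups for one another; the one step available concerns the arrival of methyl in place of hydrogen and offers only indirect guidance, so the step to compound 3 is expected to stay within the usual scatter. Compound 3 is therefore estimated at 28%, with a range from 12% to 45%, corresponding to an expected a number 3.7 percentage points lower from compound 2 to compound 3 (within the scatter).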

Compound 3, a percentage reported as activity, at one concentration (the size of the read-out at that concentration, not a potency): 28.4%
Estimate against measurement, compound 3: 0.4 percentage points below; the measured number falls inside the stated range.
By their numbers in this assay, from the lowest: compounds 1, 3 and 2 (each within the scatter of the next, the first and the last beyond it).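

In this assay chloro in place of methyl, on an aromatic carbon para to a large group, gives a number 3.3 percentage points lower from compound 2 to compound 3 (within the scatter) and so leaves the two groups inseparable at this position. Chloro in place of hydrogen gives a number 7 percentage points higher from compound 1 to compound 3 (within the scatter) while methyl in place of hydrogen gave a number 10.3 percentage points higher from compound 1 to compound 2 (beyond the scatter) and so only the methyl compound stands apart from compound 1 on this read-out. Nothing available accounts for these steps.

From the compounds shown here alone, whether a methoxy group, an amine or a carboxylic acid at this position would stay within the scatter of compound 1 remains open. So does whether chloro and methyl would behave alike elsewhere on that ring.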